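Oxadiazole series: pyridin-3-yl for phenyl on compound 2

A few compounds are considered here, and "the series" means these few. Any claim that something is new, unique, unknown or untested is made for them only; others in the source may bear on it.

Measured so far:
compound 1 `c1ccc(-c2noc(-c3ccncc3)n2)cc1`, 710000 nM
compound 2 `COc1ccc(-c2noc(-c3ccccc3)n2)cc1OC1CCCC1`, a limit only: > 1000000 nM
compound 3 `COc1ccc(-c2noc(-c3ccc(F)cc3)n2)cc1O`, a limit only: > 1000000 nM

For the measured compounds named here, in a functional assay on LNCaP cells (Homo sapiens) for antiproliferative activity, read by MTT assay, with a stated time of 24 h (a lower number here means a stronger inhibitor, a higher number a weaker inhibitor), compound 1 gives 710000 nM, the only true number in the set, and a large concentration at that. Compound 2 reports only a limit, > 1000000 nM. Compound 3 likewise reports only a limit, > 1000000 nM. Compound 2 therefore stands at the limit of > 1000000 nM in this assay, at which 2 of the 3 values shown sit; on the numbers shown it is not separated from compound 3, and only compound 1 sits below the limit.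

Compound 4 `COc1ccc(-c2noc(-c3cccnc3)n2)cc1OC1CCCC1` is compound 2 with pyridin-3-yl in place of phenyl on an aromatic carbon. Going by the values given here, no pair of measured compounds differs by this change alone, so the measured set gives no step to lean on for it. The starting point is a limit, and nothing among the three measured compounds suggests that this kind of swap moves the read-out far.

The step from compound 2 to compound 4 is expected to be a number no higher from compound 2 to compound 4 (the limit leaves the size open), that is, none beyond the scatter, with the assay most likely again reporting only a limit. Compound 4 is estimated at 1000000 nM, with a range from 300000 nM to 3000000 nM.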

Compound 4, half-maximal inhibitory concentration: > 1000000 nM
Compound 4: no number, only a limit; the forecaster's own chance of this, stated with the estimate: 65%; the middle value sits exactly at the limit.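

Compound 4 reports only a limit in this assay, > 1000000 nM, and compound 2 is also held only by a limit, so no step can be read between compound 2 and compound 4. Left open is whether pyridin-3-yl in place of phenyl moves the read-out in either direction, as neither compound has a true number.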